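Swapping a Pyridine Ring for an Ethylphenyl Ring

This account rests on a few compounds, and the source may have more. Where it says the series, first, only, none or still open, it means among the compounds named here.

Measured so far:
compound 1, `O=C(Nc1cc2cc[nH]c(=O)c2cc1Cl)C1CNCC1c1ccccn1`, 14 nM
compound 2, `NC(C(=O)Nc1cc2cc[nH]c(=O)c2cc1Cl)c1cccc(Cl)c1`, 15 nM
compound 3, `CN1CCC(C(=O)Nc2cc3cc[nH]c(=O)c3cc2Cl)CC1`, 31 nM

All three share one core and were tested in an assay on isolated protein for inhibition of Rho-associated protein kinase 2 (Homo sapiens), read by a luciferase reporter; on this read-out higher numbers stand for weaker inhibition and lower numbers for stronger inhibition. Compound 1 and compound 2 give numbers that lie within the usual scatter of each other, while compound 3 gives a higher number that falls beyond the scatter. Compound 4 `CCc1cccc(C2CNCC2C(=O)Nc2cc3cc[nH]c(=O)c3cc2Cl)c1` has not yet been measured. It differs from compound 1 in one place: 3-ethylphenyl in place of pyridin-2-yl on a saturated ring carbon. For the measured compounds named here, no pair of measured compounds shows an exchange of this kind, so its effect cannot be read from the numbers at hand. The expected step from compound 1 to compound 4 is a 1.8-fold higher number from compound 1 to compound 4 (0.25 log units; within the scatter), most likely within the scatter or a modest rise. Compound 4 is therefore estimated at 25 nM, with a range from 8 nM to 80 nM.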

Compound 4, half-maximal inhibitory concentration: 4 nM
The estimate for compound 4 lay 6.3-fold (0.80 log units) above the measured number; measured number outside the range, below it.
By their numbers in this assay, from the lowest: compound 4; then compounds 1 and 2 (each within the scatter of the next); then compound 3.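

In this assay putting 3-ethylphenyl in place of pyridin-2-yl on this saturated ring carbon gives a 3.5-fold lower number from compound 1 to compound 4 (0.54 log units; beyond the scatter) at this position. The position therefore takes a larger aromatic ring of carbon only, and the ring nitrogen of pyridin-2-yl is not required for a low number in this series. Nothing measured here explains the gain.

The exchange removes the ring nitrogen and adds the ethyl group together, so the two changes cannot be told apart; plain phenyl would separate them. From the compounds shown here alone, how an amine or a carboxylic acid in place of the ethyl group would fare also remains open.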